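Dropping the Methoxy: Expected Effect on Cell Inhibition

This account rests on a few compounds, and the source may have more. Where it says the series, first, only, none or still open, it means among the compounds named here.

Measured compounds:
compound 1 `Cc1ccc(-c2nn(-c3ccccc3)cc2C(=O)NC(=S)Nc2ccc(Cl)cc2)cc1`: 6210 nM
compound 2 `COc1ccc(-c2nn(-c3ccccc3)cc2C(=O)NC(=S)Nc2ccc(Cl)cc2)cc1`: 4760 nM

Two analogues sharing one core have been tested in a functional assay on MCF7 cells (Homo sapiens) for inhibition, read by CCK-8 assay, with a stated time of 48 h; a higher number here means a weaker inhibitor, a lower number a stronger inhibitor. Among the measured compounds shown here, compound 1 gives 6210 nM, and compound 2 gives 4760 nM; the only measured step is a 1.3-fold lower number from compound 1 to compound 2 (0.12 log units; within the scatter). Compound 2 thus stands at the lower of the two numbers, but the gap to compound 1 is within the scatter, so the two cannot be told apart.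

Compound 3 `O=C(NC(=S)Nc1ccc(Cl)cc1)c1cn(-c2ccccc2)nc1-c1ccccc1` remains to be measured. Its difference from compound 2 is hydrogen in place of methoxy on an aromatic carbon, the site being an aromatic carbon of a six-membered aromatic ring of carbon only, para to a large group. For the measured compounds named here, the one measured step, methyl to methoxy at this same site, was within the scatter, and no measured step covers removal of the group altogether. The data therefore give no reason to expect a change beyond the scatter. The expected outcome for compound 3 is the step of a 1.3-fold higher number from compound 2 to compound 3 (0.10 log units; within the scatter). The estimate for compound 3 is 6000 nM, within 2500 nM to 15000 nM.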

Compound 3, half-maximal inhibitory concentration: 6230 nM
For compound 3 the middle estimate is 1.0-fold (0.02 log units) below the measured one; low and high end bracket the measured number.
By their numbers in this assay, from the lowest: compounds 2, 1 and 3 (each within the scatter of the next).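

In this assay, hydrogen in place of methoxy gives a 1.3-fold higher number from compound 2 to compound 3 (0.12 log units; within the scatter), and hydrogen in place of methyl gives a 1.0-fold higher number from compound 1 to compound 3 (0.00 log units; within the scatter), both within the scatter. Among the compounds shown here, the earlier compounds showed only one group exchanged for another at this site, whereas the position now also appears without any group, and hydrogen, methyl and methoxy on this aromatic carbon, para to a large group, cannot be told apart in this set of three. No measured evidence is available that bears on this result.

From the compounds shown here alone, whether an amine, a carboxylic acid or a longer chain such as ethoxy at this site would produce a step beyond the scatter remains open. Going by these compounds, all three numbers come from this assay alone, so whether the same holds in any other assay is also open.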